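The compounds below may be only part of what the source reports. "The series", "measured", "known", "first", "only" and "open" are said of these compounds alone.

Measured compounds in a functional assay on K562 cells (Homo sapiens), read by MTT assay, with a stated time of 72 h; a higher number here means a weaker inhibitor, a lower number a stronger inhibitor:
compound 1 `C#Cc1cn([C@@H]2O[C@H](CO)[C@@H](O)[C@H]2O)c2ncnc(C)c12`, giving 6920 nM
compound 2 `C#Cc1cn([C@@H]2O[C@H](CO)[C@@H](O)[C@H]2O)c2ncnc(NC)c12`, giving > 20000 nM, a limit of the assay
compound 3 `CNc1ncnc2c1c(-c1ccsc1)cn2[C@@H]1O[C@H](CO)[C@@H](O)[C@H]1O`, giving > 20000 nM, a limit of the assay

Compound 2 and compound 3 both sit at the limit of > 20000 nM in this assay, at which 2 of the 3 values shown sit. Compound 1 differs from compound 2 by methyl in place of methylamino on an aromatic carbon, and this change gives an at least 2.8-fold lower number from compound 2 to compound 1 (0.46 log units; beyond the scatter). The two cores differ by thiophen-3-yl in place of ethynyl on an aromatic carbon, which gives a step that the two limits leave unreadable from compound 2 to compound 3, so nothing is read from that pair.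

Compound 4 `Cc1ncnc2c1c(-c1ccsc1)cn2[C@@H]1O[C@H](CO)[C@@H](O)[C@H]1O` has not been measured. It differs from compound 3 by methyl in place of methylamino on an aromatic carbon, the same change as from compound 2 to compound 1, at a place described in the same words. For compound 4 in this assay the step of an at least 2.0-fold lower number from compound 3 to compound 4 (0.30 log units; that floor lies within the scatter) is expected, resting on compound 3 sitting at the limit of > 20000 nM in this assay, at which 2 of the 3 values shown sit, and on the change from compound 2 to compound 1 giving an at least 2.8-fold lower number from compound 2 to compound 1 (0.46 log units; beyond the scatter). Compound 4 is estimated at 10000 nM. The expected range for compound 4 runs from 3000 nM to 40000 nM, and a limit rather than a number remains a real possibility.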

Compound 4, half-maximal inhibitory concentration: 320 nM
Compound 4: middle estimate off by 31-fold (1.49 log units), on the high side; measured number outside the range, below it.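

In this assay, methyl in place of methylamino on an aromatic carbon again lowers the number on a second core, giving an at least 62-fold lower number from compound 3 to compound 4 (1.79 log units; beyond the scatter), so the direction of the change carries across the two cores shown. Compound 3 gives > 20000 nM, a limit of the assay, so this step is a floor and not a measured size. The data do not show whether the change is worth the same on both cores: the same change on two cores in this assay, an at least 2.8-fold lower number (0.46 log units; beyond the scatter) from compound 2 to compound 1 and an at least 62-fold lower number (1.79 log units; beyond the scatter) from compound 3 to compound 4; the limit leaves it open whether they differ

On these data alone, with methyl held constant, thiophen-3-yl in place of ethynyl on an aromatic carbon gives a 22-fold lower number from compound 1 to compound 4 (1.33 log units; beyond the scatter), whereas the matching step with methylamino cannot be read, so it remains open whether this gain depends on the methyl group. Also open, as far as these compounds go, is how an ethyl group or an unsubstituted amine would read at the place now held by methyl, and whether other aryl rings would match thiophen-3-yl.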